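Swapping the amide for an aryl amine on a shared benzothiazole-free core

The compounds below may be only part of what the source reports. "The series", "measured", "known", "first", "only" and "open" are said of these compounds alone.

Measured so far:
Compound 1, `O=C(Nc1nc2ccc(NC(=O)C3CCCO3)cc2s1)C1CCCCC1`: 1.3 ug/mL
Compound 2, `CC(C)CC(=O)Nc1nc2ccc(NC(=O)c3c(Cl)cccc3Cl)cc2s1`: 0.012 ug/mL

Of the compounds shown here, two have been measured in a functional assay on WI-38 VA13 cells (Homo sapiens) for cytotoxicity; on this read-out lower numbers stand for an effect already at smaller amounts and higher numbers for an effect only at larger amounts of compound. Compound 1 gives 1.3 ug/mL. Compound 2, which carries a different group on each of the two nitrogens of the shared core, gives 0.012 ug/mL, the lowest of the two numbers; the gap to compound 1 lies well beyond the usual scatter. Only these two values are shown, and they differ in more than one place, so no single step between them can be read off.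

The next compound, compound 3, is `COc1ccccc1Nc1nc2ccc(NC(=O)c3c(Cl)cccc3Cl)cc2s1`. It keeps the 2,6-dichlorophenylcarbonyl side of compound 2 and changes the other side: 2-methoxyphenyl in place of isobutylcarbonyl on a nitrogen on an aromatic ring. Going by the values given here, no measured pair shows this kind of exchange, so its effect in this assay has to be estimated from the position of compound 2 alone. Compound 3 is expected to stay in the potent range but to lose some ground, with an estimated step of an 8.3-fold higher number from compound 2 to compound 3 (0.92 log units; beyond the scatter). For compound 3 the estimate is 0.1 ug/mL, with a range from 0.01 ug/mL to 1.5 ug/mL.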

Compound 3, half-maximal effective concentration: > 7.2 ug/mL
Compound 3: a limit, no number; the forecaster's own chance of this, stated with the estimate: 5%; middle value at least 72-fold (1.85 log units) from the limit.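

Going by these compounds alone, with the 2,6-dichlorophenylcarbonyl side held constant, this exchange gives the first single-place comparison, and the nitrogen on an aromatic ring turns out to matter greatly in this assay: the change produces an at least 600-fold higher number from compound 2 to compound 3 (2.77 log units; beyond the scatter). Compound 3 gives > 7.2 ug/mL, which is a limit of the assay and not a number. Going by these compounds, the step is therefore a minimum, and its full size remains unknown, as it rests on a value at that limit: the limit of > 7.2 ug/mL in this assay, at which 1 of the 3 values shown sits.

The exchange removes isobutylcarbonyl and brings in 2-methoxyphenyl in one move, so the compounds shown cannot separate the part played by the carbonyl from that of the aromatic ring or the methoxy group. On these data alone, how a plain phenyl, a benzoyl group or a longer acyl chain on that nitrogen would read out stays open, as does whether the same exchange would have a similar effect alongside a different group on the other nitrogen.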